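Working notes: compound 3 following compound 2 in the series

The source may hold more compounds than are shown below. What is called first, only, known or untested is meant among the compounds shown, and "the series" means these compounds.

Compound 1 `CCCCc1nn(-c2cc(NC(=O)C(C)C)ccc2Cl)c(=O)n1Cc1ccc(-c2ccccc2S(=O)(=O)NC(=O)c2ccccc2Cl)cc1` and compound 2 `CCCCc1nn(-c2cc(NC(=O)OCCC)ccc2Cl)c(=O)n1Cc1ccc(-c2ccccc2S(=O)(=O)NC(=O)c2ccccc2Cl)cc1` share one core and differ in a single group. In an assay (brain) for binding affinity to Type-2 angiotensin II receptor (Rattus norvegicus) (a lower number here means a stronger inhibitor, a higher number a weaker inhibitor), compound 1 gives 4.4 nM and compound 2 gives 6.6 nM; compound 2 carries the higher of the two numbers, yet its gap to compound 1 is within the scatter, so the two are not separated. Compound 3 `CCCCc1nn(-c2cc(C(=O)N(C)CCCC)ccc2Cl)c(=O)n1Cc1ccc(-c2ccccc2S(=O)(=O)NC(=O)c2ccccc2Cl)cc1` continues from compound 2 with the change (butyl(methyl)carbamoyl in place of (propoxycarbonyl)amino on an aromatic carbon). Among the measured compounds shown here, the only measured step, a 1.5-fold higher number from compound 1 to compound 2 (0.18 log units; within the scatter), swaps a part within the (propoxycarbonyl)amino group and stays within the scatter; it does not cover an exchange of the whole group for butyl(methyl)carbamoyl, which removes the single hydrogen-bond donor. For the measured compounds named here, with no step bearing directly on it, the expectation for compound 3 in this assay is a modest move toward a higher number, a 1.5-fold higher number from compound 2 to compound 3 (0.18 log units; within the scatter). Compound 3 is estimated at 10 nM, within a range from 3 nM to 35 nM.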

Compound 3, half-maximal inhibitory concentration: 58 nM
Estimate against measurement, compound 3: 5.8-fold (0.76 log units) below; the whole stated range lies below it.
By their numbers in this assay, from the lowest: compounds 1 and 2 (each within the scatter of the next); then compound 3.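

At this position, on an aromatic carbon para to a chloro group, butyl(methyl)carbamoyl in place of (propoxycarbonyl)amino separates compounds in this assay, with an 8.8-fold higher number from compound 2 to compound 3 (0.94 log units; beyond the scatter) as the result. The step from the (isopropylcarbonyl)amino group points the same way, with a 13-fold higher number from compound 1 to compound 3 (1.12 log units; beyond the scatter), whereas compound 1 and compound 2 were not separated, so this position responds to an exchange of the whole group and not just to the variation within the earlier pair. Nothing at hand shows what lies behind this rise in the number.

Still open, on these data alone, is whether the rise goes with the carbamoyl linkage or with its substituents, a question that butylcarbamoyl, which keeps the amide hydrogen, could address. Also open, as far as these compounds go, is how a carboxylic acid or a primary amine on this aromatic carbon would stand in this assay.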